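The source may hold more compounds than are shown below. What is called first, only, known or untested is meant among the compounds shown, and "the series" means these compounds.

Measured in a functional assay on K562 cells (Homo sapiens) for cytotoxicity, read by MTT assay, with a stated time of 48 h; on this read-out lower numbers stand for stronger inhibition and higher numbers for weaker inhibition:
- compound 1 `CCOC(=O)/C=C/c1ccc2c(c1)C(=O)C(=O)N2Cc1ccc(OC)cc1`: 10 nM
- compound 2 `CC(C)(C)OC(=O)/C=C/c1ccc2c(c1)C(=O)C(=O)N2Cc1ccc(Br)cc1`: 290 nM
- compound 3 `COC(=O)/C=C/c1ccc2c(c1)C(=O)C(=O)N2Cc1ccc(OC)cc1`: 3 nM

Of these three, compound 3 gives the lowest number, 3 nM. The next compound to be tested, compound 4 `COc1ccc(CN2C(=O)C(=O)c3cc(/C=C/C(=O)OC(C)(C)C)ccc32)cc1`, keeps the rest of compound 3 and changes only the ester: tert-butyl in place of methyl on an oxygen next to a carbonyl group. In words, this is tert-butyl in place of methyl on an oxygen next to a carbonyl group.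

Within the data shown here, one measured step bears directly on this place. It is a 3.3-fold lower number from compound 1 to compound 3 (0.52 log units; beyond the scatter), a modest step beyond the scatter, and it ends at the methyl ester. Compound 4 moves the other way from compound 3, towards more carbon on that oxygen, and it moves further than that step did. Compound 2 also carries tert-butyl and reads 290 nM, but it has bromo where compound 3 has methoxy, so its value cannot be credited to the ester alone. Among the measured compounds shown here, no measured pair isolates tert-butyl.

For the measured compounds named here, a rise in this assay is therefore expected, somewhat larger than the one measured step. The expected change is an 8.3-fold higher number from compound 3 to compound 4 (0.92 log units; beyond the scatter). For compound 4 the estimated value is 25 nM, with an expected range from 6 nM to 120 nM.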

Compound 4, half-maximal inhibitory concentration: 50 nM
Beside the measured number, compound 4's estimate is 2.0-fold (0.30 log units) below it; the measured number falls inside the stated range.
By their numbers in this assay, from the lowest: compound 3; then compound 1; then compound 4; then compound 2.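

Among these compounds, at this oxygen the size of the group matters more than the one earlier step could show: in this assay there is a 17-fold higher number from compound 3 to compound 4 (1.22 log units; beyond the scatter), a large step, and a 5.0-fold higher number from compound 1 to compound 4 (0.70 log units; beyond the scatter), a modest one. Among the compounds carrying methoxy on the benzyl group, the number thus rises from the methyl ester through the ethyl ester to the tert-butyl ester, and none of these compounds goes against that order. Among the compounds shown here, the tert-butyl ester also gives the first pair that isolates the other changed place, with a 5.8-fold lower number from compound 2 to compound 4 (0.76 log units; beyond the scatter), so tert-butyl and bromo each separately stand with a higher number, and the high reading of compound 2 cannot be credited to the ester alone. No measurement shown here explains either effect.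

The compounds shown leave open how an isopropyl group, a longer chain or the free carboxylic acid would read at this place, since three esters give only a short series. They also leave open whether exchanging methoxy for bromo costs as much on the methyl ester as it does on the tert-butyl ester.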